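A Longer Chain Replaces a Hydroxy Group

A few compounds are considered here, and "the series" means these few. Any claim that something is new, unique, unknown or untested is made for them only; others in the source may bear on it.

Compound 1, `O=c1cc(Cn2cc(C3CC3)nn2)c2ccc(O)cc2o1`, and compound 2, `O=c1cc(Cn2cc(CCCO)nn2)c2ccc(O)cc2o1`, share one core and differ only in the group carried on an aromatic carbon: a cyclopropyl in compound 1 and a 3-hydroxypropyl in compound 2. In a functional assay on SW-620 cells (Homo sapiens) for inhibition, read by MTT assay, with a stated time of 72 h (on this read-out higher numbers stand for weaker inhibition and lower numbers for stronger inhibition), compound 1 reaches only a limit of the assay, > 100000 nM. In this assay compound 2 likewise reaches only a limit, > 100000 nM. The step that the two limits leave unreadable from compound 1 to compound 2 therefore cannot be sized, because both values sit at the limit of > 100000 nM in this assay, at which 2 of the 2 values shown sit.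

Compound 3, `CCCCCCCCc1cn(Cc2cc(=O)oc3cc(O)ccc23)nn1`, differs from compound 2 by pentyl in place of hydroxy on a saturated chain carbon, three bonds along the chain from an aromatic carbon, so that the 3-hydroxypropyl of compound 2 becomes an octyl. For the measured compounds named here, the only measured step, from compound 1 to compound 2, is unreadable, and no measured step involves an exchange of hydroxy for pentyl. So the numbers give no direction and no size to expect in this assay; the estimate can only lean on where compound 2 stands. Compound 3 is expected at 80000 nM, somewhere between 15000 nM and 300000 nM. The expected step from compound 2 to compound 3 is an at least 1.2-fold lower number from compound 2 to compound 3 (0.09 log units; that floor lies within the scatter).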

Compound 3, half-maximal inhibitory concentration: 50900 nM
The estimate for compound 3 lay 1.6-fold (0.20 log units) above the measured number, and the stated range covers the measured number.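

For the compounds shown here, compound 3 is the first compound here to give a number rather than a limit in this assay, and it carries the octyl chain on the aromatic carbon where compound 1 has cyclopropyl and compound 2 has 3-hydroxypropyl. Exchanging hydroxy for pentyl on the chain gives an at least 1.9-fold lower number from compound 2 to compound 3 (0.29 log units; that floor lies within the scatter), and exchanging cyclopropyl for octyl on the aromatic carbon gives an at least 1.9-fold lower number from compound 1 to compound 3 (0.29 log units; that floor lies within the scatter). Both figures are only floors, so the true steps may be larger, but as printed neither gets beyond the usual scatter, and the values they start from are not numbers: the limit of > 100000 nM in this assay, at which 2 of the 3 values shown sit.

Going by these compounds, with a single number in this set, no trend with chain length can be read, and it stays open whether a shorter hexyl chain or a longer decyl chain would give a lower or a higher number than compound 3. On these data alone, it is equally open whether an octyl chain ending in an amine or a carboxylic acid would keep the number of compound 3 or return to the limit.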